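Amide tail variation on the shared core: compound 4

This account rests on a few compounds, and the source may have more. Where it says the series, first, only, none or still open, it means among the compounds named here.

Compound 1 `Cc1nn(-c2ncnc3nc[nH]c23)c2c1C(OCCc1ccccc1)CC(=O)N2` carries a phenethyloxy tail on the saturated ring carbon and in a functional assay on HEK293 cells for agonist activity at G-protein coupled receptor 39 (Homo sapiens), read by scintillation proximity assay and inositol phosphate accumulation, with a stated time of 75 min (on this read-out lower numbers stand for an effect already at smaller amounts and higher numbers for an effect only at larger amounts of compound), compound 1 gives 40 nM. Compound 2 `Cc1nn(-c2ncnc3nc[nH]c23)c2c1C(OCc1ccc(Cl)cc1Cl)CC(=O)N2` gives 243 nM, with a 6.1-fold higher number from compound 1 to compound 2 (0.78 log units; beyond the scatter). Compound 3 `Cc1nn(-c2ncnc3nc[nH]c23)c2c1C(NC(=O)Cc1cccs1)CC(=O)N2`, which swaps the ether tail for an amide-linked one, gives 244 nM; this is the highest of the three numbers, though a 1.0-fold higher number from compound 2 to compound 3 (0.00 log units; within the scatter), so compound 2 and compound 3 are not separated, while a 6.1-fold higher number from compound 1 to compound 3 (0.79 log units; beyond the scatter).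

Compound 4 `Cc1nn(-c2ncnc3nc[nH]c23)c2c1C(NC(=O)c1ccccc1)CC(=O)N2` keeps the amide link of compound 3 and changes only the group on the carbonyl carbon: phenyl in place of (thiophen-2-yl)methyl on a carbonyl carbon, that is, ((thiophen-2-yl)methyl)carbonyl becomes benzoyl. Within the data shown here, no measured step alters the group on a carbonyl carbon, so none bears directly. The nearest precedent is the tail exchange from compound 1 to compound 2 and the ether-to-amide exchange from compound 2 to compound 3, both shown above; one was modest and the other within the scatter, which suggests the tail beyond the linker tolerates aryl changes without large shifts.

Compound 4 is therefore expected to stay close to compound 3, the estimate being a 1.0-fold higher number from compound 3 to compound 4 (0.01 log units; within the scatter), i.e. no step beyond the scatter. The estimated value for compound 4 is 250 nM, within 80 nM to 800 nM.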

Compound 4, half-maximal effective concentration: 158 nM
Compound 4: the middle estimate sits 1.6-fold (0.20 log units) above what was measured, within the range that was stated.
By their numbers in this assay, from the lowest: compound 1; then compounds 4, 2 and 3 (each within the scatter of the next).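

On a carbonyl carbon, phenyl in place of (thiophen-2-yl)methyl leaves the read-out in this assay within the scatter (a 1.5-fold lower number from compound 3 to compound 4 (0.19 log units; within the scatter)), so at this place a six-membered aromatic ring of carbon only and a five-membered aromatic ring with 1 hetero atom on a methylene are not told apart. The benzamido tail is likewise not separated from the (2,4-dichlorobenzyl)oxy tail (a 1.5-fold lower number from compound 2 to compound 4 (0.19 log units; within the scatter)), which puts compound 2, compound 3 and compound 4 in one group, whereas the phenethyloxy tail of compound 1 stands apart from the benzamido tail (a 4.0-fold higher number from compound 1 to compound 4 (0.60 log units; beyond the scatter)). The amide link alone does not mark that gap, as compound 2 goes against such a reading with its ether link and its own step (a 6.1-fold higher number from compound 1 to compound 2 (0.78 log units; beyond the scatter)), and no measurement at hand accounts for the gap.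

Open, on these data alone, is whether a longer chain on the carbonyl carbon, such as phenethyl, would bring an amide close to compound 1 at 40 nM. Also open, as far as these compounds go, is how a tail ending in an amine or a carboxylic acid would read on the shared core.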